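The source may hold more compounds than are shown below. What is called first, only, known or untested is meant among the compounds shown, and "the series" means these compounds.

Measured so far in a functional assay on HepG2 cells (Homo sapiens) for cytotoxicity, read by MTT assay, with a stated time of 72 h; a lower number here means a stronger inhibitor, a higher number a weaker inhibitor:

compound 1, `Cn1ccc2c(Oc3ccc(NC(=O)c4nn(-c5ccc(Br)cc5)ccc4=O)cc3)ccnc21`: 39200 nM
compound 2, `Cn1ccc2c(Oc3ccc(NC(=O)c4nn(-c5ccc(Br)cc5F)ccc4=O)cc3)ccnc21`: 31200 nM

Within the data shown here, compound 2 and compound 1 lie within the scatter of each other in this assay; the one measured step, a 1.3-fold lower number from compound 1 to compound 2 (0.10 log units; within the scatter), does not separate them, so the position of compound 2 is simply that of a weak inhibitor alongside compound 1.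

Compound 3, `Cn1ccc2c(Oc3ccc(NC(=O)c4nn(-c5ccc(Cl)c(F)c5)ccc4=O)cc3)ccnc21`, is to be measured next. Relative to compound 2 the change is 4-chloro-3-fluorophenyl in place of 4-bromo-2-fluorophenyl on an aromatic nitrogen. Among the measured compounds shown here, the only step on record, a 1.3-fold lower number from compound 1 to compound 2 (0.10 log units; within the scatter), concerns a single fluorine added to the ring on that same aromatic nitrogen and was within the scatter. For the measured compounds named here, that step bears on the change only in part: compound 3 both relocates the fluorine on the ring and exchanges bromine for chlorine, and no measured pair addresses the halogen exchange. Going by the values given here, with one small step as the sole guide, the expected step from compound 2 to compound 3 is a 1.1-fold higher number from compound 2 to compound 3 (0.02 log units; within the scatter), that is, none beyond the scatter. Compound 3 is therefore estimated at 33000 nM in this assay, with a range from 15000 nM to 75000 nM.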

Compound 3, half-maximal inhibitory concentration: > 60000 nM
Compound 3 ended at the assay's limit (the forecaster's own chance of this, stated with the estimate: 15%); middle value at least 1.8-fold (0.25 log units) from the limit.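

In this assay compound 3 gives > 60000 nM, which is a limit of the assay and not a number. On the aromatic nitrogen, 4-chloro-3-fluorophenyl gives an at least 1.9-fold higher number from compound 2 to compound 3 (0.28 log units; that floor lies within the scatter) and an at least 1.5-fold higher number from compound 1 to compound 3 (0.18 log units; that floor lies within the scatter), so this position has now yielded a value with no readable number, while 4-bromophenyl and 4-bromo-2-fluorophenyl both gave numbers. Neither step establishes a real difference, and only floors can be stated for this change because the size of each step is hidden: the limit of > 60000 nM in this assay, at which 1 of the 3 values shown sits.

Compound 3 moves the fluorine and exchanges bromine for chlorine in one change, so the compounds shown cannot assign any part of the steps to either exchange, and a phenyl carrying chlorine alone on this nitrogen would bear on that question. Also open, as far as these compounds go, is whether any group on this ring, such as an amine or a carboxylic acid in place of the halogen, would give a number clearly apart from those of compound 1 and compound 2 in this assay.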